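The source may report more compounds than this note shows. Statements on the series, on what has been measured and on what is new or still open speak of the compounds shown alone.

In a functional assay on MCF7 cells (Homo sapiens) for cytotoxicity, read by sulforhodamine B assay (on this read-out lower numbers stand for stronger inhibition of growth and higher numbers for weaker inhibition of growth), compound 1 `CC1=CC[C@@H]([C@@](C)(O)CCCC(C)(C)NC(=S)NN)CC1` gives 15300 nM and compound 2 `CC1=CC[C@@H]([C@@](C)(O)CCCC(C)(C)NC(=S)N/N=C\c2ccccc2Cl)CC1` gives 31200 nM, the higher of the two numbers. Compound 3 `CC1=CC[C@@H]([C@@](C)(O)CCCC(C)(C)NC(=S)N/N=C\c2cccc(Cl)c2)CC1` has the same atoms as compound 2, joined differently: 3-chlorophenyl in place of 2-chlorophenyl on a carbon with a double bond to nitrogen, with 3-chlorophenyl in place of 2-chlorophenyl on a carbon with a double bond to nitrogen. For the measured compounds named here, no measured step covers this exchange. Going by the values given here, the only step available, a 2.0-fold higher number from compound 1 to compound 2 (0.31 log units; beyond the scatter), was modest and added the whole group, so in this assay little change and no favoured direction are expected. The estimated step is a 1.2-fold lower number from compound 2 to compound 3 (0.08 log units; within the scatter). For compound 3 the expected value is 26000 nM, with a range of 12000 nM to 50000 nM.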

Compound 3, concentration for 50% growth inhibition: 7350 nM
Compound 3: the middle estimate sits 3.5-fold (0.55 log units) above what was measured, outside the stated range (below it).
By their numbers in this assay, from the lowest: compound 3; then compound 1; then compound 2.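

In this assay, the place on a carbon with a double bond to nitrogen proves sensitive to where the chlorine sits: 3-chlorophenyl in place of 2-chlorophenyl gives a 4.2-fold lower number from compound 2 to compound 3 (0.63 log units; beyond the scatter) here. Adding the whole group therefore has no single direction, with a 2.1-fold lower number from compound 1 to compound 3 (0.32 log units; beyond the scatter) standing against a 2.0-fold higher number from compound 1 to compound 2 (0.31 log units; beyond the scatter) in the same read-out. No measurement at hand accounts for this difference.

As far as these compounds go, whether 4-chlorophenyl, unsubstituted phenyl or a methoxyphenyl group would follow compound 3 or compound 2 remains open.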